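Swapping an aryl group for pyrrolidinyl on a quinazoline-like core

This account rests on a few compounds, and the source may have more. Where it says the series, first, only, none or still open, it means among the compounds named here.

Measured compounds:
- compound 1 `FC(F)(F)c1ccccc1-c1nc(NCc2ccc(-c3ccc(Cl)c(Cl)c3)cc2)c2ccccc2n1`: 2200 nM
- compound 2 `FC(F)(F)c1cc(-c2ccc(CNc3nc(-c4ccccc4C(F)(F)F)nc4ccccc34)cc2)ccn1`: 4900 nM
- compound 3 `FC(F)(F)c1cccc(-c2nc(NCc3ccc(-c4cccnc4)cc3)c3ccccc3n2)c1`: "not active" (no number reported)

In an assay on a protein complex for inhibition of ubiquitin carboxyl-terminal hydrolase 1/WD repeat-containing protein 48 (Homo sapiens), read by fluorescence (on this read-out lower numbers stand for stronger inhibition and higher numbers for weaker inhibition), compound 3 gives "not active" (no number reported), so no number marks where it stands; only compounds 1 and 2 carry numbers, and those lie in the low micromolar range. Compound 4 `c1cncc(-c2ccc(CNc3nc(N4CCCC4)nc4ccccc34)cc2)c1` differs from compound 3 by pyrrolidin-1-yl in place of 3-(trifluoromethyl)phenyl on an aromatic carbon. Among the measured compounds shown here, the one measured step, a 2.2-fold higher number from compound 1 to compound 2 (0.35 log units; beyond the scatter), concerns a different part of the shared core and does not bear on this change, so nothing measured points to a direction. Given that compound 3 shows no activity, compound 4 is expected to land around 10000 nM in this assay, within 1500 nM to 60000 nM, with a real chance that only a limit is reported.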

Compound 4, half-maximal inhibitory concentration: "not active" (no number reported)
No number was reported for compound 4; there is nothing to compare the estimate with.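

Compound 3 and compound 4 both come without a number, so no step can be read between them. As far as these compounds go, whether pyrrolidin-1-yl or 3-(trifluoromethyl)phenyl gives the stronger inhibition on this shared core stays open. No supporting data bear on either result.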